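Changing the Aryl Group on the Ring Nitrogen

The source may hold more compounds than are shown below. What is called first, only, known or untested is meant among the compounds shown, and "the series" means these compounds.

Measured compounds:
compound 1: `Nc1scc(CN2CCN(c3ccc(F)cc3Cl)CC2)c1C(=O)c1ccc(Cl)cc1` — -6.2%
compound 2: `COc1ccc(N2CCN(Cc3csc(N)c3C(=O)c3ccc(Cl)cc3)CC2)cc1` — 0%

Of the compounds shown here, two sharing one core have been measured in a functional assay on CHO cells with adenosine receptor A1 (Homo sapiens) as the target, read by cAMP accumulation and immunoassay, with a stated time of 6 min, tested at 0.1 uM; a lower number here means a stronger effect, a higher number a weaker effect of the compound at the concentration tested. In this assay compound 1 gives -6.2%, and compound 2 gives 0%. Going by the values given here, of the two numbers, that of compound 2 is the one at zero, but the only measured step, a number 6.2 percentage points higher from compound 1 to compound 2 (within the scatter), lies within the scatter, so the two compounds are not distinguished by these data; both show essentially no effect at the concentration tested.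

Compound 3 is `Nc1scc(CN2CCN(c3cccc(C(F)(F)F)c3)CC2)c1C(=O)c1ccc(Cl)cc1`. It differs from compound 2 by 3-(trifluoromethyl)phenyl in place of 4-methoxyphenyl on an amine nitrogen in a ring. Among the compounds with values here, the one step that bears on this change is the exchange of one aryl group for another on the same ring nitrogen, from compound 1 to compound 2, and that step was within the scatter. On that basis the step from compound 2 to compound 3 is expected to be no change at the digits printed from compound 2 to compound 3 (within the scatter), that is, no change beyond the scatter. Compound 3 is therefore estimated to give 0% in this assay, with a range from -12% to 12%.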

Compound 3, a percentage reported as activity, at one concentration (the size of the read-out at that concentration, not a potency): -30%
Compound 3: the middle estimate sits 30 percentage points above what was measured; measured number outside the range, below it.
By their numbers in this assay, from the lowest: compound 3; then compounds 1 and 2 (each within the scatter of the next).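

The aryl group on this ring nitrogen is not without consequence in this assay: 3-(trifluoromethyl)phenyl in place of 4-methoxyphenyl gives a number 30 percentage points lower from compound 2 to compound 3 (beyond the scatter), a stronger effect at the concentration tested. Set against 2-chloro-4-fluorophenyl, the same group gives a number 23.8 percentage points lower from compound 1 to compound 3 (beyond the scatter), so the exchange between compound 1 and compound 2, which stayed within the scatter, does not hold for every aryl group at this position, and among the three compounds only compound 3 stands apart. No measurement shown here accounts for this shift.

The compounds shown do not separate the trifluoromethyl group from its place on the phenyl ring, and an unsubstituted phenyl or a 4-(trifluoromethyl)phenyl group on the same nitrogen would be needed to tell these apart. The read-out also comes from a single concentration, so it leaves open how the potency of compound 3 compares with that of compound 1 and compound 2.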